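The source may hold more compounds than are shown below. What is called first, only, known or untested is meant among the compounds shown, and "the series" means these compounds.

Measured compounds:
compound 1 `COc1ccc(C(=O)/C=C/c2cc(-c3cc(OC)c(OC)c(OC)c3)n[nH]2)cc1OC` — 5720 nM
compound 2 `COc1ccc(C(=O)/C=C/c2cc(-c3cc(OC)c(OC)c(OC)c3)n[nH]2)cc1` — 7610 nM

Compound 1 and compound 2 were both tested in a functional assay on MCF7 cells (Homo sapiens) for inhibition, read by sulforhodamine B assay, with a stated time of 48 h; on this read-out lower numbers stand for higher toxicity in this test and higher numbers for lower toxicity in this test. Compound 2 holds the highest of the two numbers, but its nearest neighbour is compound 1 and the step of a 1.3-fold higher number from compound 1 to compound 2 (0.12 log units; within the scatter) lies within the scatter, so the two cannot be told apart on this read-out.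

Compound 3 `COc1cc(-c2cc(/C=C/C(=O)c3ccc(F)c(F)c3)[nH]n2)cc(OC)c1OC` has not yet been measured. Compared with compound 2, it carries 3,4-difluorophenyl in place of 4-methoxyphenyl on a carbonyl carbon. Among the compounds with values here, the only measured step, from compound 1 to compound 2, concerns a different exchange on the same aryl group and was too small to stand out; no measured pair shows an aryl swap of this kind, so there is nothing in the data that points to a large step in either direction in this assay.

Compound 3 is therefore expected to give about 8000 nM, with a range from 3000 nM to 25000 nM. The step from compound 2 that this estimate means is a 1.1-fold higher number from compound 2 to compound 3 (0.02 log units; within the scatter), which is expected to stay within the scatter.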

Compound 3, concentration lethal to 50% of the cells: > 100000 nM
Compound 3 gave a limit, no number (the forecaster's own chance of this, stated with the estimate: 5%); at least 12-fold (1.09 log units) between middle value and limit.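

Within the data shown here, the aryl group on the carbonyl carbon is not indifferent in this assay, which the earlier pair could not show, since the only step then available, a 1.3-fold higher number from compound 1 to compound 2 (0.12 log units; within the scatter), removed one methoxy and left the two compounds indistinguishable. Putting 3,4-difluorophenyl in place of 4-methoxyphenyl on that carbon gives an at least 13-fold higher number from compound 2 to compound 3 (1.11 log units; beyond the scatter), and putting it in place of 3,4-dimethoxyphenyl gives an at least 17-fold higher number from compound 1 to compound 3 (1.24 log units; beyond the scatter), so with the rest of the molecule unchanged, this exchange alone moves the read-out well beyond the scatter, towards lower toxicity in this test. Compound 3 yields a limit and not a number, so these steps fix only a minimum size and the true distance stays unknown: the limit of > 100000 nM in this assay, at which 1 of the 3 values shown sits.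

The compounds shown do not separate the departure of every methoxy from the arrival of the two fluorines, and a plain phenyl on the carbonyl carbon would be needed to tell these apart. They also leave open how this position responds to a different kind of group, such as an amine or a carboxylic acid on that ring.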